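The source may report more compounds than this note shows. Statements on the series, on what has been measured and on what is new or still open speak of the compounds shown alone.

Among the compounds with values here, in a physicochemical assay for solubility, read by nephelometry, in phosphate buffer, measured as kinetic solubility, at pH 6.5 (on this read-out higher numbers stand for higher solubility and lower numbers for lower solubility), compound 2 `CCOC(=O)C1=C(C)N/C(=C/c2cc(C)n(Cc3ccc(C(F)(F)F)cc3)c2C)C1=O` gives 1.6 ug/mL and compound 3 `CC1=C(C(=O)OC(C)(C)C)C(=O)/C(=C\c2cc(C)n(-c3ccccc3C(F)(F)F)c2C)N1` stands level with it at 1.6 ug/mL on the numbers so far. Compound 1 `CCOC(=O)C1=C(O)/C(=C\c2cc(C)n(-c3ccc(F)cc3)c2C)N=C1C` gives 3.1 ug/mL which lies within the scatter of both. Compound 4 `CC1=C(C(N)=O)C(=O)/C(=C\c2cc(C)n(-c3ccccc3C(F)(F)F)c2C)N1` differs from compound 3 in a single place, with amino in place of tert-butoxy on a carbonyl carbon so that tert-butoxycarbonyl becomes carbamoyl. Within the data shown here, no measured pair shows this change, which leaves the forecast without direct support. The step expected in this assay runs upward, a 2.5-fold higher number from compound 3 to compound 4 (0.40 log units; beyond the scatter) and a little beyond the scatter. For compound 4 the estimated solubility is 4 ug/mL with an expected range from 1.5 ug/mL to 15 ug/mL on this read-out.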

Compound 4, solubility: 6.3 ug/mL
Compound 4: middle estimate off by 1.6-fold (0.20 log units), on the low side, within the range that was stated.
By their numbers in this assay, from the lowest: compounds 2, 3 and 1 (each within the scatter of the next); then compound 4.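

Within the data shown here, replacing tert-butoxy with amino on this carbonyl carbon, so that tert-butoxycarbonyl becomes carbamoyl, gives in this assay a 3.9-fold higher number from compound 3 to compound 4 (0.60 log units; beyond the scatter), the first single-place comparison in the set. The earlier compounds shown here differ from one another in more than one place, so none could isolate this position. Nothing measured here accounts for the rise.

Still open, from the compounds shown here alone, is how a carboxylic acid or a methylamino group on the same carbonyl carbon would read. Also open, going by these compounds, is whether carbamoyl would give a similar step on the rest of compound 1 or compound 2.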